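The source may report more compounds than this note shows. Statements on the series, on what has been measured and on what is new or still open speak of the compounds shown alone.

Measured compounds in this series:
- compound 1 `CCN1CC(NC(=O)[C@@H]2CCCN(S(=O)(=O)c3ccc(S(=O)(=O)N(CC)CC)cc3)C2)C1`: > 30000 nM
- compound 2 `CCN(CC)C(=O)c1ccc(S(=O)(=O)N2CCC[C@@H](C(=O)N3CCN(c4nc(C(C)C)no4)CC3)C2)cc1`: 1400 nM
- compound 3 `CCN(CC)S(=O)(=O)c1ccc(S(=O)(=O)N2CCC[C@@H](C(=O)N3CCN(C(=O)OC(C)(C)C)CC3)C2)cc1`: 200 nM

In a functional assay on BXPC-3 cells (Homo sapiens) for inhibition, read by MTT assay, with a stated time of 7 days (on this read-out higher numbers stand for weaker inhibition and lower numbers for stronger inhibition), compound 2 gives 1400 nM, the higher of the two numbers obtained. Compound 3 sits at 200 nM, a gap that lies beyond the scatter. For compound 1 the value > 30000 nM is a limit of this assay, not a number (the limit of > 30000 nM in this assay, at which 1 of the 3 values shown sits). Compound 2 and compound 3 differ in more than one place, so their two values show only the gap itself.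

Compound 4 `CCNS(=O)(=O)c1ccc(S(=O)(=O)N2CCC[C@@H](C(=O)N3CCN(c4nc(C(C)C)no4)CC3)C2)cc1` is obtained from compound 2 by a single change: ethylsulfamoyl in place of diethylcarbamoyl on an aromatic carbon. Among the measured compounds shown here, no measured pair isolates this change, so no step size can be read off. Compound 4 is expected to land near compound 2, with at most a modest move toward a lower number. The step this estimate means, a 1.4-fold lower number from compound 2 to compound 4 (0.15 log units; within the scatter), is expected to stay within the scatter. Compound 4 is estimated at 1000 nM, between 300 nM and 3500 nM.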

Compound 4, half-maximal inhibitory concentration: 6900 nM
Beside the measured number, compound 4's estimate is 6.9-fold (0.84 log units) below it; the whole stated range lies below it.
By their numbers in this assay, from the lowest: compound 3; then compound 2; then compound 4. At a limit, above all of these: compound 1.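

In this assay, among the compounds shown here, the exchange of diethylcarbamoyl for ethylsulfamoyl gives the first step that isolates a single change: a 4.9-fold higher number from compound 2 to compound 4 (0.69 log units; beyond the scatter). The position on the aromatic carbon, para to a large group, is therefore not indifferent to the group it carries, at least with the rest of compound 2 held fixed. Nothing measured here accounts for the size of this step.

The compounds shown leave open whether the step follows from the sulfonyl replacing the carbonyl or from one ethyl replacing two, and an ethylcarbamoyl group at this position would separate these. Going by these compounds, how a carboxylic acid or a longer chain would read here also stays open, and steps among the other compounds cannot be read, since they differ in more than one place.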